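This account rests on a few compounds, and the source may have more. Where it says the series, first, only, none or still open, it means among the compounds named here.

Measured in a functional assay on Jurkat cells (Homo sapiens) for cytotoxicity, with a stated time of 72 h; a higher number here means that more compound is needed for the effect, a lower number that less compound is needed:
- compound 1 `C=C[C@@](C)(/C=C/c1ccc(O)cc1)CC/C=C(\C)CO`: > 49000 nM, a limit
- compound 2 `C=C[C@@](C)(/C=C/c1ccc(O)cc1)CC/C=C(C)/C=C/C(=O)OCC`: > 49000 nM, a limit

Compound 2 gives only a limit, > 49000 nM. Among the measured compounds shown here, the series so far shows (the limit of > 49000 nM in this assay, at which 2 of the 2 values shown sit). Compound 3 `C=C[C@@](C)(/C=C/c1ccc(O)cc1)CC/C=C(C)/C=C/C(=O)OCc1ccccc1` differs by phenyl in place of methyl on a saturated chain carbon bound to an oxygen next to a carbonyl group: ethoxycarbonyl to benzyloxycarbonyl. For the measured compounds named here, the only measured step, a step that the two limits leave unreadable from compound 1 to compound 2, involves a different place and gives no size to carry over, so no step beyond the scatter is expected in this assay. The estimated change is an at least 1.0-fold lower number from compound 2 to compound 3 (0.03 log units; that floor lies within the scatter). Compound 3 is expected at 45000 nM, with an estimated range of 20000 nM to 90000 nM.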

Compound 3, half-maximal effective concentration: > 49000 nM
Compound 3: no number, only a limit; the forecaster's own chance of this, stated with the estimate: 70%; middle value at least 1.0-fold (0.03 log units) away from the limit.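

In this assay, compound 2 and compound 3 give only limits, so no step can be read between them: the limit of > 49000 nM in this assay, at which 3 of the 3 values shown sit.

The compounds shown leave open what concentration, if any, produces the effect for either compound.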